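Ester chain variation on the core of compound 3

The compounds below may be only part of what the source reports. "The series", "measured", "known", "first", "only" and "open" are said of these compounds alone.

Measured compounds:
compound 1 `CCCCC1=C(C(=O)OCC)C(c2cccc([N+](=O)[O-])c2)C(C(=O)OCC)=C(C)N1` — 20 nM
compound 2 `CCOC(=O)C1=C(C)NC(/C=C/c2ccc([N+](=O)[O-])cc2)=C(C(=O)OCC)C1c1cccc([N+](=O)[O-])c1` — 1940 nM
compound 3 `COC(=O)C1=C(C)NC(C)=C(C(=O)OCc2ccccc2)C1c1cccc([N+](=O)[O-])c1` — 25 nM

All three numbers come from a functional assay on HEK293 cells for antagonist activity at Voltage-dependent L-type calcium channel subunit alpha-1C (Oryctolagus cuniculus), read by FLIPR; on this read-out higher numbers stand for weaker inhibition and lower numbers for stronger inhibition. Compound 3 stands second highest of the three, close to compound 1 and within the scatter of it, while compound 2 lies far higher, beyond the scatter. Compound 4 `COC(=O)C1=C(C)NC(C)=C(C(=O)OCCCOc2ccccc2)C1c1cccc([N+](=O)[O-])c1` is the next compound in the series; its difference from compound 3 is 2-phenoxyethyl in place of phenyl on a saturated chain carbon bound to an oxygen next to a carbonyl group. Going by the values given here, the only measured step, a 97-fold higher number from compound 1 to compound 2 (1.99 log units; beyond the scatter), concerns a substituent on a double-bonded ring carbon and not the ester chain, so it does not bear on this change. Among the compounds with values here, no measured step touches the ester chain, and an expectation must rest on that gap. The number for compound 4 in this assay is therefore estimated near that of compound 3, with a 1.3-fold higher number from compound 3 to compound 4 (0.11 log units; within the scatter) as the expected step, not beyond the scatter. Compound 4 is expected at 32 nM, within 8 nM to 130 nM.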

Compound 4, half-maximal inhibitory concentration: 9 nM
For compound 4 the middle estimate is 3.6-fold (0.55 log units) above the measured one, within the range that was stated.
By their numbers in this assay, from the lowest: compound 4; then compounds 1 and 3 (each within the scatter of the next); then compound 2.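

In this assay, 3-phenoxypropyl in place of benzyl gives a 2.8-fold lower number from compound 3 to compound 4 (0.44 log units; beyond the scatter). Going by these compounds alone, this is the first measured step at the ester chain, and it shows that this position accepts a longer chain carrying an oxygen with stronger, not weaker, inhibition. No available evidence explains this step. The compounds shown leave open whether the chain length or the oxygen accounts for the step, and whether an amine or a carboxylic acid in place of the phenoxy part would keep inhibition at this level.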